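The source may hold more compounds than are shown below. What is called first, only, known or untested is meant among the compounds shown, and "the series" means these compounds.

Compound 1 `Oc1ccc(-c2nnc(SCCCN3CCN(c4nc5ccccc5o4)CC3)o2)cc1`: 181000 nM
Compound 2 `COc1ccc(-c2nnc(SCCCN3CCN(c4nc5ccccc5s4)CC3)o2)cc1`: 90300 nM
Compound 3 `Clc1ccc(-c2nnc(SCCCN3CCN(c4nc5ccccc5s4)CC3)o2)cc1`: 110000 nM

In a functional assay on A549 cells (Homo sapiens) for inhibition, read by MTT assay, with a stated time of 72 h (a lower number here means a stronger inhibitor, a higher number a weaker inhibitor), compound 3 gives 110000 nM and lies within the scatter of both compound 2 and compound 1. Compound 4 `Oc1ccc(-c2nnc(SCCCN3CCN(c4nc5ccccc5s4)CC3)o2)cc1` differs from compound 3 by hydroxy in place of chloro on an aromatic carbon, 4-chlorophenyl to 4-hydroxyphenyl. Within the data shown here, the one measured step at this place is a 1.2-fold higher number from compound 2 to compound 3 (0.09 log units; within the scatter) and involves chloro and methoxy, not hydroxy. Among the measured compounds shown here, compound 1, the only measured compound with a hydroxy group, gives 181000 nM on a different core. No shift beyond the scatter is therefore expected in this assay, and the expected step is a 1.2-fold higher number from compound 3 to compound 4 (0.07 log units; within the scatter) within that scatter. The estimate for compound 4 is 130000 nM with an expected range from 65000 nM to 260000 nM as its limits.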

Compound 4, half-maximal inhibitory concentration: 62100 nM
Compound 4: middle estimate off by 2.1-fold (0.32 log units), on the high side; measured number outside the range, below it.
By their numbers in this assay, from the lowest: compounds 4, 2, 3 and 1 (each within the scatter of the next, the first and the last beyond it).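

In this assay, 4-chlorophenyl to 4-hydroxyphenyl gives a 1.8-fold lower number from compound 3 to compound 4 (0.25 log units; within the scatter), and hydrogen in place of methyl on the oxygen gives a 1.5-fold lower number from compound 2 to compound 4 (0.16 log units; within the scatter), so on this core hydroxy, methoxy and chloro are not separated beyond the scatter. With hydroxy held constant, 1,3-benzothiazol-2-yl in place of 1,3-benzoxazol-2-yl gives a 2.9-fold lower number from compound 1 to compound 4 (0.46 log units; beyond the scatter), a modest step and the only new one beyond the scatter. No evidence on hand accounts for these steps. Open, going by these compounds, is whether an amine or a carboxylic acid in place of hydroxy would stay within the scatter, and whether a longer chain on the sulfur would shift the number.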